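The compounds below may be only part of what the source reports. "The series", "measured", "known", "first", "only" and "open" are said of these compounds alone.

For the measured compounds named here, only two compounds have been measured so far in an in vitro ADME assay on microsomes from liver (Mus musculus) for pharmacokinetics, read by LC-MS, with a stated time of 10 min, tested at 1 uM (on this read-out lower numbers stand for slow clearance and higher numbers for fast clearance), and compound 2 (`CN1C[C@H](C(=O)Nc2ccc(Cl)cn2)[C@@H](c2ccc(/C=C/C(=O)Nc3ccccc3N)cc2)C1`) stands lowest of them at 31 mL/min/kg on this read-out. Compound 1 (`Cc1cc(NC(=O)[C@H]2CN(C)C[C@@H]2c2ccc(/C=C/C(=O)Nc3ccccc3N)cc2)ccc1Cl`) gives 65 mL/min/kg there. Compound 3 (`CN1C[C@H](C(=O)NC2CC2)[C@@H](c2ccc(/C=C/C(=O)Nc3ccccc3N)cc2)C1`) differs from compound 2 at a single place: cyclopropyl in place of 5-chloropyridin-2-yl on an amide-type nitrogen so cyclopropyl sits in place of 5-chloropyridin-2-yl on an amide-type nitrogen.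

Going by the values given here, one measured step bears on this change. It is a 2.1-fold lower number from compound 1 to compound 2 (0.32 log units; beyond the scatter) with 5-chloropyridin-2-yl in place of 4-chloro-3-methylphenyl on an amide-type nitrogen. That step is modest, though beyond the usual scatter, and it concerns the same place in the molecule. Among the compounds with values here, no measured compound carries cyclopropyl, however, and one step cannot set a direction for a different group. In this assay the expected change is small, with an estimated 1.1-fold lower number from compound 2 to compound 3 (0.04 log units; within the scatter) and no firm direction beyond the scatter. For compound 3 the estimate is 28 mL/min/kg and the expected range runs from 12 mL/min/kg to 65 mL/min/kg given how little evidence there is.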

Compound 3, clearance: 7 mL/min/kg
Compound 3: the middle estimate sits 4.0-fold (0.60 log units) above what was measured, outside the stated range (below it).
By their numbers in this assay, from the lowest: compound 3; then compound 2; then compound 1.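

In this assay this amide-type nitrogen proves able to carry a much larger change than the earlier pair suggested: a 2.1-fold lower number from compound 1 to compound 2 (0.32 log units; beyond the scatter) came from exchanging one aromatic group for another, while cyclopropyl in place of 5-chloropyridin-2-yl gives a 4.4-fold lower number from compound 2 to compound 3 (0.65 log units; beyond the scatter) on the same read-out. Cyclopropyl in place of 4-chloro-3-methylphenyl gives a 9.3-fold lower number from compound 1 to compound 3 (0.97 log units; beyond the scatter) in the same direction, so among these three compounds the one without an aromatic ring at this place has the lowest clearance number, and neither aromatic compound goes against that order. Nothing in the data shown explains why the number falls at this position.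

Only one non-aromatic group is shown here, so it remains open whether the low number belongs to cyclopropyl itself or would also appear with a cyclobutyl ring, an isopropyl group or a plain methyl group on this nitrogen. On these data alone, it also remains open how an unsubstituted phenyl ring would read there, which would separate the effect of the ring from that of its chlorine and methyl substituents.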